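Swap of the amine-bound benzyl-type group on a shared core

The compounds below may be only part of what the source reports. "The series", "measured", "known", "first", "only" and "open" are said of these compounds alone.

Compound 1 `COc1ccc(CN2CCC(CCOC(c3ccccc3)c3ccccc3)CC2)cc1` gives 27.8 nM in an assay on cell membranes for binding affinity to sodium-dependent dopamine transporter (Rattus norvegicus); a higher number here means a weaker inhibitor, a lower number a stronger inhibitor.
Compound 2 `c1ccc(C(OCCC2CCN(Cc3cc4ccccc4s3)CC2)c2ccccc2)cc1` gives 172 nM in this assay.

Within the data shown here, compound 2 holds the highest of the two numbers in this assay; its only neighbour is reached by a 6.2-fold higher number from compound 1 to compound 2 (0.79 log units; beyond the scatter). Compound 3 `Nc1ccc(CN2CCC(CCOC(c3ccccc3)c3ccccc3)CC2)cc1` differs from compound 2 by 4-aminophenyl in place of 1-benzothiophen-2-yl on a saturated chain carbon bound to an amine nitrogen in a ring. Among the measured compounds shown here, the single step that bears on this change, a 6.2-fold higher number from compound 1 to compound 2 (0.79 log units; beyond the scatter), raised the number when 1-benzothiophen-2-yl took the place of 4-methoxyphenyl at the same position; moving from 1-benzothiophen-2-yl to 4-aminophenyl is expected to undo most of that rise, a step of about a 4.9-fold lower number from compound 2 to compound 3 (0.69 log units; beyond the scatter) in this assay. Compound 3 is therefore estimated at 35 nM, with a range of 12 nM to 110 nM.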

Compound 3, half-maximal inhibitory concentration: 101 nM
Compound 3: middle estimate off by 2.9-fold (0.46 log units), on the low side; low and high end bracket the measured number.
By their numbers in this assay, from the lowest: compound 1; then compounds 3 and 2 (each within the scatter of the next).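

In this assay, 4-aminophenyl and 1-benzothiophen-2-yl on a saturated chain carbon bound to an amine nitrogen in a ring cannot be told apart (a 1.7-fold lower number from compound 2 to compound 3 (0.23 log units; within the scatter)). The weaker binding seen on moving away from compound 1 is thus not confined to 1-benzothiophen-2-yl, as amino in place of methoxy on an aromatic carbon also weakens it (a 3.6-fold higher number from compound 1 to compound 3 (0.56 log units; beyond the scatter)). No measurement at hand explains either step.

Still open, from the compounds shown here alone, is how 4-hydroxybenzyl or unsubstituted benzyl at this position would compare with the 4-methoxyphenyl of compound 1.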